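A few compounds are considered here, and "the series" means these few. Any claim that something is new, unique, unknown or untested is made for them only; others in the source may bear on it.

Two thiosemicarbazone analogues sharing one core have been measured so far. Compound 1 `Cc1ccnc(/C(N)=N/NC(=S)N2CCCC2)c1` gives 69% in a functional assay on A-375 cells (Homo sapiens) for cytotoxicity, read by MTT assay, with a stated time of 72 h, tested at 1 uM; on this read-out higher numbers stand for more inhibition of growth at the one concentration tested and lower numbers for less inhibition of growth. Compound 2 `Cc1cccc(/C(N)=N/NC(=S)N2CCCC2)n1`, which carries its methyl at a different position of the same ring, gives only 13.6% in this assay. Compound 2 therefore stands lowest of the two numbers, and its distance to compound 1 lies well beyond the scatter of the measurement.

The next step leads from compound 2 to compound 3 `N/C(=N\NC(=S)N1CCCC1)c1ccccn1`, the parent without any methyl on the ring. The change is hydrogen in place of methyl on an aromatic carbon.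

Among the compounds with values here, no step between two measured compounds matches this change, so its size cannot be read from what has been measured. Since compound 1 shows that the ring can carry a methyl and still give 69%, while compound 2 sits far lower, the unsubstituted compound 3 is expected to fall somewhere between the two, with considerable uncertainty. Compound 3 is estimated at 40%, with a range from 10% to 75%, which means an expected step of a number 26.4 percentage points higher from compound 2 to compound 3 (beyond the scatter) upward in this assay.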

Compound 3, percent growth inhibition at one concentration: 65.7%
Compound 3: middle estimate off by 25.7 percentage points, on the low side; low and high end bracket the measured number.
By their numbers in this assay, from the lowest: compound 2; then compounds 3 and 1 (each within the scatter of the next).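

Among these three compounds, the low number does not come from having a methyl on the ring as such, but from a methyl at one particular place: on the aromatic carbon next to the ring nitrogen, meta to a large group. In this assay, hydrogen in place of methyl at that carbon gives a number 52.1 percentage points higher from compound 2 to compound 3 (beyond the scatter), a large step that restores growth inhibition, whereas the same exchange at the carbon that holds the methyl of compound 1 gives a number 3.3 percentage points lower from compound 1 to compound 3 (within the scatter), which lies within the scatter, so at that other place the methyl leaves the read-out effectively unchanged. Nothing in the data at hand accounts for this sharp dependence on the place of the methyl.

On these data alone, it remains open whether the low number is specific to methyl or would also appear with another group next to the ring nitrogen, such as an ethyl, a methoxy, a chlorine or an amine. As far as these compounds go, it is equally open how far the other place tolerates a group larger than methyl, such as an ethyl or a longer chain.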